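Replacing isopropoxy with 2-bromoanilino in a pyrrolinone series

The source may report more compounds than this note shows. Statements on the series, on what has been measured and on what is new or still open speak of the compounds shown alone.

Compound 1 `CC(C)OC1=C(C(=O)c2ccccc2)C(c2ccc(Br)cc2)N(CCCn2ccnc2)C1=O`: 8720 nM
Compound 2 `Cc1ccc(NC2=C(C(=O)c3ccccc3)C(c3ccc(Br)cc3)N(CCCn3ccnc3)C2=O)cc1`: 29400 nM
Compound 3 `O=C(C1=C(Nc2cccc(Br)c2)C(=O)N(CCCn2ccnc2)C1c1ccc(Br)cc1)c1ccccc1`: 15800 nM

In a functional assay on A549 cells (Homo sapiens) for antiproliferative activity, read by MTT assay, with a stated time of 72 h (a lower number here means a stronger inhibitor, a higher number a weaker inhibitor), compound 1 gives the lowest of the three numbers shown; compound 3 sits within the scatter of it, while compound 2 lies beyond it. Compound 4 `O=C(C1=C(Nc2ccccc2Br)C(=O)N(CCCn2ccnc2)C1c1ccc(Br)cc1)c1ccccc1` differs from compound 1 in one place: (2-bromophenyl)amino in place of isopropoxy on a double-bonded ring carbon. Among the compounds with values here, two measured steps bear on this change, both swapping the isopropoxy for an arylamino group: a 3.4-fold higher number from compound 1 to compound 2 (0.53 log units; beyond the scatter) and a 1.8-fold higher number from compound 1 to compound 3 (0.26 log units; within the scatter). The step of a 1.9-fold lower number from compound 2 to compound 3 (0.27 log units; within the scatter) shows the two aryl groups differ little from each other. A third arylamino variant is therefore expected to land near or somewhat above compound 1. Compound 4 is estimated at 15000 nM, with a range from 7000 nM to 35000 nM. This corresponds to an expected step of a 1.7-fold higher number from compound 1 to compound 4 (0.24 log units; within the scatter).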

Compound 4, half-maximal inhibitory concentration: 20100 nM
The estimate for compound 4 lay 1.3-fold (0.13 log units) below the measured number, within the range that was stated.
By their numbers in this assay, from the lowest: compounds 1, 3, 4 and 2 (each within the scatter of the next, the first and the last beyond it).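

In this assay the change gives a 2.3-fold higher number from compound 1 to compound 4 (0.36 log units; beyond the scatter) and so, like compound 2, puts an arylamino group beyond the scatter of the isopropoxy compound, though compound 3 goes against this. Among the arylamino compounds, moving the bromine gives a 1.3-fold higher number from compound 3 to compound 4 (0.10 log units; within the scatter) and replacing 4-methylphenyl with 2-bromophenyl gives a 1.5-fold lower number from compound 2 to compound 4 (0.17 log units; within the scatter) and both steps stay within the scatter. No evidence is available that explains these steps.

The compounds shown leave open whether a methoxy or a benzylamino group on this carbon would give a lower number than compound 1.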